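The source may report more compounds than this note shows. Statements on the series, on what has been measured and on what is new or still open speak of the compounds shown alone.

Measured compounds and their values:

- Compound 2, `CCNC(=O)[C@H]1O[C@@H](n2cnc3c(NC4CC4)nc(Cl)nc32)[C@H](O)[C@@H]1O`: 0.676 nM
- Compound 3, `CCNC(=O)[C@H]1O[C@@H](n2cnc3c(NCc4cccc(I)c4)nc(Cl)nc32)[C@H](O)[C@@H]1O`: 0.891 nM
- Compound 1, `CNc1nc(Cl)nc2c1ncn2[C@@H]1O[C@H](C(=O)N2CCOCC2)[C@@H](O)[C@H]1O`: 3890 nM

In an assay on CHO cells for displacement of a labelled ligand from adenosine receptor A3 (Homo sapiens) (a lower number here means a stronger inhibitor, a higher number a weaker inhibitor), compound 3 gives 0.891 nM. Among the three numbers known, that is the second highest; compound 2 sits nearest, and compound 1 sits furthest away, its value a far weaker result than either of the other two. Among the compounds with values here, the one single-site step known, a 1.3-fold higher number from compound 2 to compound 3 (0.12 log units; within the scatter), swaps groups on a nitrogen on an aromatic ring and barely moves the number.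

Compound 4, `O=C(NCc1cccc(C(F)(F)F)c1)[C@H]1O[C@@H](n2cnc3c(NCc4cccc(I)c4)nc(Cl)nc32)[C@H](O)[C@@H]1O`, is not yet measured in this assay. It differs from compound 3 at a different spot: 3-(trifluoromethyl)phenyl in place of methyl on a saturated chain carbon bound to an amide-type nitrogen. Within the data shown here, no measured pair changes this amide side alone, so none of the known steps bears directly on it. Compound 1 carries a different amide and a different group on the aromatic nitrogen and gives 3890 nM, but with two changes at once it shows only that altering the amide region can go with a much weaker result.

With nothing directly comparable, the expectation for compound 4 is a weaker result than compound 3, a step of a 10-fold higher number from compound 3 to compound 4 (1.00 log units; beyond the scatter), carrying wide uncertainty. Compound 4 is therefore estimated at 9 nM, within a range from 1.5 nM to 60 nM.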

Compound 4, inhibition constant: 355 nM
Compound 4: middle estimate off by 39-fold (1.60 log units), on the low side; measured number outside the range, above it.
By their numbers in this assay, from the lowest: compounds 2 and 3 (each within the scatter of the next); then compound 4; then compound 1.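

In this assay, the amide side of the molecule proves highly sensitive to change: with the 3-iodobenzyl group on the aromatic nitrogen held constant, replacing ethyl on the amide nitrogen with 3-(trifluoromethyl)benzyl gives a 400-fold higher number from compound 3 to compound 4 (2.60 log units; beyond the scatter). The only earlier single-site step, a 1.3-fold higher number from compound 2 to compound 3 (0.12 log units; within the scatter), lay on the aromatic nitrogen and stayed within the scatter, so this is the first change at a single site shown to move the number far beyond it. Nothing among the data shown explains why this swap has such a strong effect.

Compound 4 combines an added aromatic ring with a trifluoromethyl group, so the compounds shown cannot tell which part of the new group accounts for the step; a plain benzyl or a longer chain such as propyl on the amide nitrogen would help to separate these parts. From the compounds shown here alone, it also remains open whether the same amide change would have a similar effect with the cyclopropyl group of compound 2 on the aromatic nitrogen.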